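Replacing a Dimethylphenyl with a Fluorophenyl on a Sulfonamide

The source may hold more compounds than are shown below. What is called first, only, known or untested is meant among the compounds shown, and "the series" means these compounds.

Of the compounds shown here, three have been measured in a physicochemical assay for lipophilicity, at pH 7.4; on this read-out higher numbers stand for higher lipophilicity and lower numbers for lower lipophilicity. Compound 1 `CCc1ccc(N(CC(C)C)S(=O)(=O)c2ccc3c(c2)C(=O)N(C2CCOCC2)C3)cc1` gives 3.64. Compound 2 `Cc1ccc(N(CC(C)C)S(=O)(=O)c2ccc3c(c2)C(=O)CC(C2CCOCC2)O3)c(C)c1` gives 4.28, the highest of the three numbers. Compound 3 `CCc1ccc(N(CC(C)C)S(=O)(=O)c2ccc3c(c2)C(=O)C[C@@H](C2CCOCC2)O3)cc1` gives 4.2, which lies within the usual scatter of the number for compound 2, so these two cannot be ranked against each other; the number for compound 1 lies beyond the scatter below that of compound 2. No pair among these three differs in a single place, so no single step can be read off from the measured set.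

Compound 4 `CC(C)CN(c1ccccc1F)S(=O)(=O)c1ccc2c(c1)C(=O)CC(C1CCOCC1)O2` has not yet been measured in this assay. It differs from compound 2 in one place: 2-fluorophenyl in place of 2,4-dimethylphenyl on a sulfonamide nitrogen. Within the data shown here, since no measured pair isolates this change, the expectation rests only on the counts given for the group that leaves and the group that enters. The expected step is a number 0.78 log units lower from compound 2 to compound 4 (beyond the scatter), downward and beyond the scatter. Compound 4 is therefore estimated at 3.5, with a range from 3 to 4.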

Compound 4, distribution coefficient: 3.44
Estimate against measurement, compound 4: 0.06 log units above, within the range that was stated.
By their numbers in this assay, from the lowest: compounds 4 and 1 (each within the scatter of the next); then compounds 3 and 2 (each within the scatter of the next).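

In this assay, among these compounds, 2-fluorophenyl in place of 2,4-dimethylphenyl on the sulfonamide nitrogen gives a number 0.84 log units lower from compound 2 to compound 4 (beyond the scatter), the first step here that isolates a single change. It shows that, with the rest of the molecule held the same, the aromatic group on this nitrogen can by itself move the number beyond the scatter. Both methyl groups leave and a fluorine enters in this one change, so the step cannot be divided among them, and nothing available explains its size.

As far as these compounds go, whether the same replacement gives a step of similar size on the core of compound 1 remains open. Also open, from the compounds shown here alone, is where a plain phenyl or a pyridine ring on this nitrogen would fall, and either could help separate the part played by the methyl groups from that of the fluorine.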